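An Indole Replaces Pyridine in a Cytotoxicity Screen

The source may hold more compounds than are shown below. What is called first, only, known or untested is meant among the compounds shown, and "the series" means these compounds.

Compound 2 `CC(C)N(Cc1cccc(OCCCCCC(=O)O)c1)C(=O)c1ccc(-c2ccncc2)cc1` was tested in an ADME assay on HEK293 cells (Homo sapiens) for cytotoxicity, read by CellTiter-Glo and resazurin assay, with a stated time of 72 h; on this read-out higher numbers stand for an effect only at larger amounts of compound and lower numbers for an effect already at smaller amounts. In that assay compound 2 gives > 26000 nM, which is a limit of the assay and not a measured number. Two relatives were run as well. Compound 2 differs from compound 1 `CC(C)N(Cc1cccc(OCCCCCC(=O)O)c1)C(=O)c1ccccc1` by pyridin-4-yl in place of hydrogen on an aromatic carbon; in this assay compound 1 gives > 26000 nM, again a limit. Compound 3 `CC(=O)c1cccc(-c2ccc(C(=O)N(Cc3cccc(OCCCCCC(=O)O)c3)C(C)C)cc2)c1` carries 3-acetylphenyl in place of that hydrogen; in this assay compound 3 gives > 26000 nM, also a limit. The steps a step that the two limits leave unreadable from compound 1 to compound 2, a step that the two limits leave unreadable from compound 1 to compound 3 and a step that the two limits leave unreadable from compound 2 to compound 3 therefore cannot be read, because of the limit of > 26000 nM in this assay, at which 3 of the 3 values shown sit. Compound 4 `CC(C)N(Cc1cccc(OCCCCCC(=O)O)c1)C(=O)c1ccc(-c2ccc3cc[nH]c3c2)cc1` is not yet measured. It differs from compound 2 in one place: 1H-indol-6-yl in place of pyridin-4-yl on an aromatic carbon. Among the measured compounds shown here, with every step so far hidden behind the same limit, no size or direction can be taken from them, and the expectation is that compound 4 also shows no effect up to that limit. The estimated step is a step that the limit leaves unreadable from compound 2 to compound 4, within the scatter. Compound 4 is thus expected at 30000 nM, with a range from 12000 nM to 80000 nM.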

Compound 4, half-maximal effective concentration: > 26000 nM
Compound 4 ended at the assay's limit; the forecaster's own chance of this, stated with the estimate: 85%; the middle value is on the limit's open side.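

Among the compounds shown here, compound 4 sits at the same assay limit as compound 1, compound 2 and compound 3, so no step to compound 4 can be read in this assay: the limit of > 26000 nM in this assay, at which 4 of the 4 values shown sit. The compounds shown leave open whether any of them affects these cells at larger amounts, and whether swapping the group at this place would change that.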